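Swapping a vinyl group for an epoxide on the core

The source may report more compounds than this note shows. Statements on the series, on what has been measured and on what is new or still open speak of the compounds shown alone.

Two compounds sharing one aromatic core have been examined in an ADME assay for pharmacokinetics, read by HPLC, in phosphate buffer, with a stated time of 72 h, at pH 7.4, tested at 250 uM; on this read-out lower numbers stand for a shorter-lived compound and higher numbers for a longer-lived compound. Compound 1 is `O=C1C=CC(=O)N1c1cc(C(F)(F)F)cc(C(F)(F)F)c1` and compound 2 is `C=Cc1cc(C(F)(F)F)cc(C(F)(F)F)c1`. Compound 1 gives < 0.017 h in this assay, which is a limit of the measurement rather than a number. Compound 2 gives > 50 h in this assay, likewise a limit. Compound 2 therefore stands at the long-lived end of the two results shown, and the single measured step, an at least 2900-fold higher number from compound 1 to compound 2 (3.46 log units; beyond the scatter), is large and rests on the two limits the limit of < 0.017 h in this assay, at which 1 of the 2 values shown sits, and (the limit of > 50 h in this assay, at which 1 of the 2 values shown sits).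

Compound 3 is `FC(F)(F)c1cc(C2CO2)cc(C(F)(F)F)c1`. It differs from compound 2 by oxiran-2-yl in place of vinyl on an aromatic carbon. Among the measured compounds shown here, no measured step covers this exact exchange; the one step known concerns a different group in the same position, so it gives only a loose guide. Because the change from compound 1 to compound 2 (an at least 2900-fold higher number from compound 1 to compound 2 (3.46 log units; beyond the scatter)) shows how strongly this position can move the half-life, a step beyond the scatter in this assay is plausible, most likely toward a lower number. Compound 3 is estimated at 30 h in this assay, within a range from 5 h to 200 h, which would mean an expected step of an at least 1.6-fold lower number from compound 2 to compound 3 (0.22 log units; that floor lies within the scatter).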

Compound 3, half-life: > 50 h
Compound 3 ended at the assay's limit; the forecaster's own chance of this, stated with the estimate: 40%; middle value at least 1.6-fold (0.22 log units) away from the limit.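

With oxiran-2-yl on this aromatic carbon, a second group besides vinyl reaches the long-lived limit of this assay, so the very short half-life of compound 1 does not extend to every small group placed here, and a three-membered ring holding oxygen does not pull the compound away from that limit. Exchanging the five-membered ring group for oxiran-2-yl gives an at least 2900-fold higher number from compound 1 to compound 3 (3.46 log units; beyond the scatter), a large step whose short-lived end is a limit and not a number: the limit of < 0.017 h in this assay, at which 1 of the 3 values shown sits. The step between vinyl and oxiran-2-yl cannot be read, as compound 2 and compound 3 both stand at a limit of the assay and not at a number: the limit of > 50 h in this assay, at which 2 of the 3 values shown sit.

As far as these compounds go, how far past that limit the half-lives of compound 2 and compound 3 lie remains unknown, and with it any real difference between vinyl and oxiran-2-yl. Also open, from the compounds shown here alone, is whether other groups on this aromatic carbon, such as an amine, a carboxylic acid or a longer chain, would stay at the long-lived limit or fall toward the value of compound 1.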